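A Piperazine Ring Replaces the Hydroxyethylamine Chain

The source may report more compounds than this note shows. Statements on the series, on what has been measured and on what is new or still open speak of the compounds shown alone.

Compound 2 `Cc1cc(NCCO)nc(SCc2nc3ccccc3[nH]2)n1` sits at the bottom of the two measured values. In a functional assay on ECa-109 cells (Homo sapiens) for cytotoxicity, read by MTT assay, with a stated time of 72 h (a higher number here means a weaker inhibitor, a lower number a stronger inhibitor), compound 2 reaches only a limit of the assay, > 100000 nM, and no true number exists for it (the limit of > 100000 nM in this assay, at which 1 of the 2 values shown sits). Compound 1 `Cc1cc(Nc2ccc(Cl)cc2)nc(SCc2nc3ccccc3[nH]2)n1` gives 20400 nM in this assay. Going by the values given here, the single measured step, an at least 4.9-fold higher number from compound 1 to compound 2 (0.69 log units; beyond the scatter), shows that exchanging 4-chlorophenyl for 2-hydroxyethyl on that nitrogen weakened inhibition beyond the scatter.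

Compound 3 `Cc1cc(N2CCNCC2)nc(SCc2nc3ccccc3[nH]2)n1` differs from compound 2 by piperazin-1-yl in place of (2-hydroxyethyl)amino on an aromatic carbon. Among the compounds with values here, no measured step covers this exact change; the only available step points toward weak activity whenever the 4-chlorophenyl group is absent. Compound 3 is therefore expected to stay near the limit, with an estimated value of 100000 nM and a range from 30000 nM to 300000 nM. The expected shift is a number no higher from compound 2 to compound 3 (the limit leaves the size open), essentially no change beyond the scatter.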

Compound 3, half-maximal inhibitory concentration: > 100000 nM
Compound 3 gave a limit, no number; the forecaster's own chance of this, stated with the estimate: 60%; the middle value sits exactly at the limit.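

Putting piperazin-1-yl in place of (4-chlorophenyl)amino on this aromatic carbon gives an at least 4.9-fold higher number from compound 1 to compound 3 (0.69 log units; beyond the scatter) in this assay. This is a second replacement of the (4-chlorophenyl)amino group that loses measurable activity, and here the incoming group is a ring rather than an open chain. The step from compound 2 to compound 3 cannot be read, so the ring and the chain cannot be ranked against each other: the limit of > 100000 nM in this assay, at which 2 of the 3 values shown sit.

Going by these compounds, of the three compounds, only compound 1 gives a true number, so it remains open which part of its (4-chlorophenyl)amino group matters. A plain phenylamino group without the chlorine, or a cyclohexylamino group without the aromatic ring, would separate the role of the chlorine from that of the ring.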